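This account rests on a few compounds, and the source may have more. Where it says the series, first, only, none or still open, it means among the compounds named here.

Three compounds have been measured in a functional assay for agonist activity at 5-hydroxytryptamine receptor 1B (Homo sapiens); a higher number here means a weaker inhibitor, a lower number a stronger inhibitor:

compound 1, `CC(C)NCCCOc1cccc2ccccc12`: 7660 nM
compound 2, `CN(C)CCCCOc1cccc2ccccc12`: 470 nM
compound 3, `CNCCOc1cccc2ccccc12`: 26 nM

Compound 3 gives the lowest number of the three, its nearest neighbour being compound 2 (an 18-fold lower number from compound 2 to compound 3 (1.26 log units; beyond the scatter)), and compound 1 lies furthest away (a 290-fold lower number from compound 1 to compound 3 (2.47 log units; beyond the scatter)). Compound 4, `CCNCCOc1cccc2ccccc12`, differs from compound 3 by methyl in place of hydrogen on a saturated chain carbon bound to an amine nitrogen. For the measured compounds named here, no measured step isolates this change: the steps from compound 1 and compound 2 to compound 3 alter the amine substituents and the chain length together, so they only show that the amine end matters. A small step is therefore expected for compound 4, a 1.5-fold higher number from compound 3 to compound 4 (0.19 log units; within the scatter), with an estimate of 40 nM in this assay, ranging from 12 nM to 130 nM.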

Compound 4, inhibition constant: 66 nM
Compound 4: middle estimate off by 1.7-fold (0.22 log units), on the low side, and the stated range covers the measured number.
By their numbers in this assay, from the lowest: compound 3; then compound 4; then compound 2; then compound 1.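

In this assay, methyl in place of hydrogen on a saturated chain carbon bound to an amine nitrogen, which turns methylamino into ethylamino, gives a small but real change, with a 2.5-fold higher number from compound 3 to compound 4 (0.40 log units; beyond the scatter). The steps that alter the chain length and the amine together are larger, with a 7.1-fold lower number from compound 2 to compound 4 (0.85 log units; beyond the scatter) and a 120-fold lower number from compound 1 to compound 4 (2.06 log units; beyond the scatter), so this single addition accounts for little of the spread seen so far. Nothing available explains the change at this position. From the compounds shown here alone, whether propylamino or a primary amine would keep this number low remains open.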